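From methoxycarbonyl to hydroxymethyl: compound 1 and compound 4

This account rests on a few compounds, and the source may have more. Where it says the series, first, only, none or still open, it means among the compounds named here.

- compound 1 `COC(=O)C[C@@H]1C[C@@H](O)[C@H](C)[C@H](c2ccccc2)N1`: 6500 nM 
- compound 2 `COC(=O)C[C@H]1C[C@@H](O)[C@H](C)[C@@H](c2ccccc2)N1`: 35200 nM 
- compound 3 `COC(=O)C[C@H]1C[C@H](O)[C@H](C)[C@@H](c2ccccc2)N1`: 41100 nM 

In a functional assay on HeLa cells (Homo sapiens) for cytotoxicity, read by MTT assay (a lower number here means a stronger inhibitor, a higher number a weaker inhibitor), compound 1 stands lowest of the three, and the other two compounds lie beyond the scatter from it. The change to compound 4 `C[C@H]1[C@H](O)C[C@@H](CCO)N[C@H]1c1ccccc1` is hydroxymethyl in place of methoxycarbonyl on a saturated chain carbon bound to a saturated ring carbon. Within the data shown here, no measured step covers this change. All three steps alter configuration only, so they serve merely as a gauge of how far values move in this small series: a 5.4-fold higher number from compound 1 to compound 2 (0.73 log units; beyond the scatter) and a 6.3-fold higher number from compound 1 to compound 3 (0.80 log units; beyond the scatter) are modest, while a 1.2-fold higher number from compound 2 to compound 3 (0.07 log units; within the scatter) stays within the scatter. With compound 1 at 6500 nM as the lowest number, a modest upward move of similar size is expected, with wide uncertainty. The expected change is an estimated 2.5-fold higher number from compound 1 to compound 4 (0.39 log units; beyond the scatter) in this series. Compound 4 is estimated at 16000 nM with an expected range from 4000 nM to 60000 nM in this assay.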

Compound 4, half-maximal inhibitory concentration: 31500 nM
Compound 4: middle estimate off by 2.0-fold (0.29 log units), on the low side; the measured number falls inside the stated range.
By their numbers in this assay, from the lowest: compound 1; then compounds 4, 2 and 3 (each within the scatter of the next).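

In this assay, the chain end proves not to be a silent place: hydroxymethyl in place of methoxycarbonyl on a saturated chain carbon bound to a saturated ring carbon gives a 4.8-fold higher number from compound 1 to compound 4 (0.69 log units; beyond the scatter), a modest step. Among these compounds, every earlier step altered configuration only, so this is the first reading of a change in the atoms themselves, and it shows that the methoxycarbonyl of compound 1 can be replaced with a move of modest size, upward in number. Nothing at hand accounts for this step, since the available facts on the series concern configuration alone.

Among the compounds shown here, the single pair leaves open whether a carboxylic acid, an amine or a longer chain at this place would move the number further or return it. It also leaves open whether hydroxymethyl would give a step of similar size on the configurations of compound 2 and compound 3.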